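Cytotoxicity of a hydroxyalkyl-to-alkyl swap on the core

The source may hold more compounds than are shown below. What is called first, only, known or untested is meant among the compounds shown, and "the series" means these compounds.

Measured compounds in an ADME assay on HeLa cells (Homo sapiens) for cytotoxicity, read by ATP content, with a stated time of 3 days; on this read-out higher numbers stand for lower toxicity in this test and lower numbers for higher toxicity in this test:
compound 1 `CC(C)CCn1c(Cn2c(=O)n(C3CC3)c3ccncc32)nc2ncccc21`, reported only as a limit: > 100000 nM
compound 2 `O=c1n(Cc2nc3ncccc3n2CCCCO)c2cnccc2n1C1CC1`, reported only as a limit: > 100000 nM
compound 3 `O=c1n(Cc2nc3cnccc3n2CCCCO)c2cnccc2n1C1CC1`, reported only as a limit: > 100000 nM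

Compound 3 stands at the limit of this assay ; its value is not a number. Compound 4 `CC(C)CCn1c(Cn2c(=O)n(C3CC3)c3ccncc32)nc2cnccc21` differs from it by isopropyl in place of 2-hydroxyethyl on a saturated chain carbon, two bonds along the chain from an aromatic nitrogen. The same exchange, run in the opposite direction on the other core, is the step that the two limits leave unreadable from compound 1 to compound 2; both ends of that step sit at the limit, so its size cannot be read. Among the compounds with values here, no measured step in this assay is readable, since (the limit of > 100000 nM in this assay, at which 3 of the 3 values shown sit). The only expectation that the data support is that compound 4 also stays at or beyond the limit, and the expected step that the limit leaves unreadable from compound 3 to compound 4 is therefore none beyond the scatter. For compound 4 the estimate in this assay is 150000 nM, with a range from 50000 nM to 500000 nM.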

Compound 4, half-maximal cytotoxic concentration: > 100000 nM
Compound 4 gave a limit, no number (the forecaster's own chance of this, stated with the estimate: 85%); the middle value lies beyond the limit too.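

Compound 3 and compound 4 both stand only as limits in this assay, so no step between them can be read: the limit of > 100000 nM in this assay, at which 4 of the 4 values shown sit.

The compounds shown leave open how far each lies beyond that limit, and whether exchanging 2-hydroxyethyl for isopropyl changes the read-out at all.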